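This account rests on a few compounds, and the source may have more. Where it says the series, first, only, none or still open, it means among the compounds named here.

Of the compounds shown here, three sharing one core have been measured for activation of the channel. Compound 1 `Cc1cc(NC(=O)Cn2nnc(-c3ccccc3F)n2)n(C2CCCCC2)n1` gives 187 nM in an assay on HEK293 cells for activation of Kir3.1/Kir3.2 (Homo sapiens), read by thallium flux; a higher number here means that more compound is needed for the effect, a lower number that less compound is needed. Compound 2 `Cc1cc(NC(=O)Cn2nnc(-c3ccnc(F)c3)n2)n(C2CCCCC2)n1` gives 441 nM in this assay, and compound 3 `COc1ccc(-c2nnn(CC(=O)Nc3cc(C)nn3C3CCCCC3)n2)cc1` gives 175 nM. Compound 3 has the lowest of the three numbers, though its gap to compound 1 is within the scatter a 1.1-fold lower number from compound 1 to compound 3 (0.03 log units; within the scatter), and only its gap to compound 2 is beyond it a 2.5-fold lower number from compound 2 to compound 3 (0.40 log units; beyond the scatter). Compound 4 `Cc1cc(NC(=O)Cn2nnc(-c3ccc(C(F)(F)F)cc3)n2)n(C2CCCCC2)n1` has not yet been measured. It differs from compound 3 in one place: trifluoromethyl in place of methoxy on an aromatic carbon, on an aromatic carbon of a six-membered aromatic ring of carbon only, para to a large group. All three measured steps alter the same aryl group on the tetrazole. Exchanging one phenyl substituent for another left the number essentially unchanged a 1.1-fold lower number from compound 1 to compound 3 (0.03 log units; within the scatter), whereas placing a nitrogen in the ring shifted it modestly a 2.4-fold higher number from compound 1 to compound 2 (0.37 log units; beyond the scatter). Since the change from compound 3 to compound 4 keeps the phenyl ring and only swaps its substituent, the step expected in this assay is small a 1.3-fold higher number from compound 3 to compound 4 (0.10 log units; within the scatter). Compound 4 is therefore estimated at 220 nM, with a range from 100 nM to 500 nM.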

Compound 4, half-maximal effective concentration: 241 nM
Estimate against measurement, compound 4: 1.1-fold (0.04 log units) below; the measured number falls inside the stated range.
By their numbers in this assay, from the lowest: compounds 3, 1, 4 and 2 (each within the scatter of the next, the first and the last beyond it).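

In this assay, trifluoromethyl in place of methoxy, para to a large group, stays within the scatter (a 1.4-fold higher number from compound 3 to compound 4 (0.14 log units; within the scatter)), as does 4-(trifluoromethyl)phenyl in place of 2-fluorophenyl (a 1.3-fold higher number from compound 1 to compound 4 (0.11 log units; within the scatter)), so compounds 1, 3 and 4 cannot be told apart despite their different phenyl substituents. Compound 4 also stays within the scatter of the 2-fluoropyridin-4-yl compound (a 1.8-fold lower number from compound 2 to compound 4 (0.26 log units; within the scatter)), which weakens the earlier picture of compound 2 standing apart from the phenyl compounds: that separation holds for compounds 1 and 3, but compound 4 goes against it. Nothing available here accounts for these numbers or explains why the substituents give such similar results.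

As far as these compounds go, it remains open whether a carboxylic acid, an amine or a longer alkoxy chain at this same place would move the number beyond the scatter from compound 3. The compounds shown also leave open how far the number depends on the rest of the shared core, which is the same in all four.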